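Amide nitrogen substituent and distribution coefficient

The source may report more compounds than this note shows. Statements on the series, on what has been measured and on what is new or still open speak of the compounds shown alone.

Measured so far:
compound 1, `COc1cc(-c2cc(C(=O)O)c3ccccc3n2)ccc1OCC(=O)Nc1ccccc1C`, 0.8
compound 2, `COc1cc(-c2cc(C(=O)O)c3ccccc3n2)ccc1OCC(=O)Nc1ccc(F)cc1`, 1.1
compound 3, `COc1cc(-c2cc(C(=O)O)c3ccccc3n2)ccc1OCC(=O)NCc1ccco1`, -0.3

The three share a core and differ only in the group on the amide-type nitrogen. In a physicochemical assay for lipophilicity, using the shake flask method, in phosphate buffer, measured as octanol-water partition, at pH 7.4 (on this read-out higher numbers stand for higher lipophilicity and lower numbers for lower lipophilicity), compound 3 gives the lowest number of the three: the step of a number 1.10 log units lower from compound 1 to compound 3 (beyond the scatter) and the step of a number 1.40 log units lower from compound 2 to compound 3 (beyond the scatter) are both beyond the scatter, whereas a number 0.30 log units higher from compound 1 to compound 2 (within the scatter) lies within it, so compound 1 and compound 2 are not separated in this assay.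

Compound 4, `COc1cc(-c2cc(C(=O)O)c3ccccc3n2)ccc1OCC(=O)NC1CCCCC1`, has not been measured. It differs from compound 3 in one place: cyclohexyl in place of (furan-2-yl)methyl on an amide-type nitrogen. The two large measured steps bear on this change in that each installs the (furan-2-yl)methyl group in place of an aryl group and each lowers this assay clearly beyond the scatter. Within the data shown here, no measured step brings in a cyclohexyl or any non-aromatic ring, so the size of that side of the change is not pinned down by the numbers in hand. An upward step beyond the scatter, of about the size seen for the two aryl groups, is expected: a number 1.40 log units higher from compound 3 to compound 4 (beyond the scatter). Compound 4 is therefore estimated at 1.1, within a range from 0.5 to 1.7.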

Compound 4, distribution coefficient: 0.8
The estimate for compound 4 lay 0.30 log units above the measured number; low and high end bracket the measured number.
By their numbers in this assay, from the lowest: compound 3; then compounds 1, 4 and 2 (each within the scatter of the next).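

The cyclohexyl group shows that an aromatic ring on the amide-type nitrogen is not required for the higher numbers in this assay: the step of a number 1.10 log units higher from compound 3 to compound 4 (beyond the scatter) is beyond the scatter, although both groups count 6 heavy atoms. Compound 4 is not separated from the two aryl amides, since the step of a number 0.30 log units lower from compound 2 to compound 4 (within the scatter) and the step of no change at the digits printed from compound 1 to compound 4 (within the scatter) both lie within the scatter, so among these four compounds only compound 3 stands apart. The low number of compound 3 can therefore no longer be read simply as the loss of an aryl group on the amide-type nitrogen, as compound 4 has no aryl group there either.

The compounds shown do not separate the furan ring from the methylene link in the group of compound 3, a question on which a benzyl or cyclohexylmethyl group on the same nitrogen would bear, and an open chain such as n-butyl or a group carrying an amine remains equally open. Nothing in hand gives a measured reason for any of these numbers.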